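The source may report more compounds than this note shows. Statements on the series, on what has been measured and on what is new or still open speak of the compounds shown alone.

In a functional assay on HeLa cells (Homo sapiens) for cytotoxicity, read by MTT assay, with a stated time of 72 h (on this read-out lower numbers stand for stronger inhibition and higher numbers for weaker inhibition), compound 1 (`Cn1ccc2c(Oc3ccc(NC(=O)c4cc5cccnc5n(-c5ccc(C(F)(F)F)cc5Cl)c4=O)cc3)ncnc21`) gives 174000 nM, compound 2 (`Cn1ccc2c(Oc3ccc(NC(=O)c4cc5cccnc5n(-c5ccc(F)cc5)c4=O)cc3F)ncnc21`) gives 4250 nM, and compound 3 (`O=C(Nc1ccc(Oc2ncnc3[nH]ccc23)c(F)c1)c1cc2cccnc2n(-c2ccc(F)cc2)c1=O`) gives 3720 nM. Compound 3 thus stands level with compound 2 and far under compound 1. Compound 4 (`O=C(Nc1ccc(Oc2ncnc3[nH]ccc23)c(F)c1)c1cc2cccnc2n(-c2ccc(C(F)(F)F)cc2Cl)c1=O`) departs from compound 3 by one change: 2-chloro-4-(trifluoromethyl)phenyl in place of 4-fluorophenyl on an aromatic nitrogen, with 2-chloro-4-(trifluoromethyl)phenyl in place of 4-fluorophenyl on an aromatic nitrogen. Among the measured compounds shown here, the one measured step, a 1.1-fold lower number from compound 2 to compound 3 (0.06 log units; within the scatter), concerns a different place and says little here. Compound 1 carries the entering group and gives 174000 nM, but it differs from compound 2 in more than that group, so only part of that gap is expected to carry over. In this assay, the expected change, beyond the scatter and towards a higher number, is an 8.1-fold higher number from compound 3 to compound 4 (0.91 log units; beyond the scatter). For compound 4 the estimated value is 30000 nM, with an expected range from 6000 nM to 150000 nM.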

Compound 4, half-maximal inhibitory concentration: 96800 nM
Compound 4: the middle estimate sits 3.2-fold (0.51 log units) below what was measured; measured number inside the range.
By their numbers in this assay, from the lowest: compounds 3 and 2 (each within the scatter of the next); then compounds 4 and 1 (each within the scatter of the next).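

In this assay the group on the aromatic nitrogen proves decisive: with the rest of compound 3 unchanged, 2-chloro-4-(trifluoromethyl)phenyl in place of 4-fluorophenyl gives a 26-fold higher number from compound 3 to compound 4 (1.42 log units; beyond the scatter) and so weakens inhibition well beyond the scatter. Unlike the gap to compound 1, this step isolates the change at this position from any other difference. Nothing measured here accounts for the size of this step.

The entering group brings chlorine and trifluoromethyl together, so the compounds shown leave open which of the two carries the step. As far as these compounds go, how a 4-methoxyphenyl group or a phenyl bearing an amine would behave at this position also remains open.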